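A few compounds are considered here, and "the series" means these few. Any claim that something is new, unique, unknown or untested is made for them only; others in the source may bear on it.

Measured in a functional assay on the whole organism (Hindlimb, strain albino) with Mus musculus as the target, in the maximal electroshock model, with a stated time of 0.5 h; on this read-out higher numbers stand for an effect only at larger amounts of compound and lower numbers for an effect already at smaller amounts:
compound 1 `COc1ccc(C2CC(Nc3nc4ccc([N+](=O)[O-])cc4s3)=NN2C(C)=O)cc1`: 145 umol/kg
compound 2 `CC(=O)N1N=C(Nc2nc3ccc([N+](=O)[O-])cc3s2)CC1c1ccc(O)cc1`: 162 umol/kg
compound 3 `CC(=O)N1N=C(Nc2nc3ccc([N+](=O)[O-])cc3s2)CC1c1ccc(Cl)cc1`: 132 umol/kg

Compound 1 stands level with the other two: a 1.1-fold higher number from compound 1 to compound 2 (0.05 log units; within the scatter) and a 1.1-fold lower number from compound 1 to compound 3 (0.04 log units; within the scatter), and a 1.2-fold lower number from compound 2 to compound 3 (0.09 log units; within the scatter) is no larger than the scatter either. Compound 4 `COc1ccc(C2CC(Nc3nc4ccccc4s3)=NN2C(C)=O)cc1` carries a change at a different place: hydrogen in place of nitro on an aromatic carbon. Among the compounds with values here, no measured step covers this change, so the small steps above are only a weak guide. In this assay, from the compounds shown here alone, no step beyond the scatter is expected, though either direction remains open. The estimated step is a 1.0-fold higher number from compound 1 to compound 4 (0.01 log units; within the scatter). The expected value for compound 4 is 150 umol/kg, with an estimated range of 70 umol/kg to 320 umol/kg.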

Compound 4, dose for half-maximal effect: 226 umol/kg
The estimate for compound 4 lay 1.5-fold (0.18 log units) below the measured number; the range from low to high includes it.
By their numbers in this assay, from the lowest: compounds 3, 1, 2 and 4 (each within the scatter of the next).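

In this assay, hydrogen in place of nitro on the fused system's aromatic carbon gives a 1.6-fold higher number from compound 1 to compound 4 (0.19 log units; within the scatter). The nitro group is therefore not needed for a dose to be read in this model, and this position, like the aromatic substituent varied across compounds 1, 2 and 3, shows no step beyond the scatter so far. Nothing available bears on why the read-out holds across this change.

From the compounds shown here alone, whether an amine or a carboxylic acid at this carbon would behave like hydrogen and nitro remains open. Also open, going by these compounds, is whether chloro or hydroxy in place of methoxy reads the same on the core of compound 4.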